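The compounds below may be only part of what the source reports. "The series", "measured", "known", "first", "only" and "open" are said of these compounds alone.

Measured so far:
- compound 1, `CN(CCCCON)C[C@H]1O[C@@H](n2cnc3c(N)ncnc32)[C@H](O)[C@@H]1O`: 18 nM
- compound 2, `CN(CCC(N)=O)C[C@H]1O[C@@H](n2cnc3c(N)ncnc32)[C@H](O)[C@@H]1O`: 7000 nM

In an assay on isolated protein for inhibition of S-adenosylmethionine decarboxylase proenzyme (Homo sapiens) (on this read-out lower numbers stand for stronger inhibition and higher numbers for weaker inhibition), compound 1 gives 18 nM and stands lowest of the two numbers; the nearest number is that of compound 2 with 7000 nM. Going by the values given here, the one step within the measured pair, a 390-fold higher number from compound 1 to compound 2 (2.59 log units; beyond the scatter), concerns the chain that carries the aminooxy group, a carbamoyl in place of 2-(aminooxy)ethyl on a saturated chain carbon two bonds along the chain from an amine nitrogen. It shows that the 2-(aminooxy)ethyl chain of compound 1 is tied to its low number, but it says nothing about the fused ring system.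

Compound 3, `Cc1nc2c(N)ncnc2n1[C@@H]1O[C@H](CN(C)CCCCON)[C@@H](O)[C@H]1O`, keeps the whole chain and the shared core of compound 1 and differs only by methyl in place of hydrogen on an aromatic carbon, on an aromatic carbon of the five-membered ring, between two ring nitrogen atoms, next to the ring atom that bears a large group. Among the compounds with values here, no measured step touches this position, so the step from compound 1 to compound 3 in this assay is expected to be small, in either direction, and most likely within the scatter: a 1.5-fold lower number from compound 1 to compound 3 (0.18 log units; within the scatter). Compound 3 is therefore estimated at 12 nM, with a range from 3 nM to 50 nM.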

Compound 3, half-maximal inhibitory concentration: 5 nM
The estimate for compound 3 lay 2.4-fold (0.38 log units) above the measured number; low and high end bracket the measured number.
By their numbers in this assay, from the lowest: compound 3; then compound 1; then compound 2.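

In this assay, methyl in place of hydrogen on an aromatic carbon gives a 3.6-fold lower number from compound 1 to compound 3 (0.56 log units; beyond the scatter), a modest step that lies beyond the scatter and is the only step shown that changes the shared core rather than the chain. This position, between two ring nitrogen atoms and next to the ring atom that bears a large group, therefore takes a methyl without loss, and with the rest of compound 1 unchanged the number moves lower rather than higher. Nothing available explains this shift.

Going by these compounds, this is a single substituent at a single position, so it remains open whether the trend continues with ethyl, follows with a halogen such as chlorine, or reverses with an amine or a methoxy group at the same carbon. On these data alone, it is also open whether the methyl has a similar effect on the carbamoyl chain of compound 2 or only alongside the 2-(aminooxy)ethyl chain of compound 1 and compound 3.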